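Nitro position shift carried over to the trimethoxy pair

The source may report more compounds than this note shows. Statements on the series, on what has been measured and on what is new or still open speak of the compounds shown alone.

Compound 1 `CN(C)c1ccc(/C=C2\CCC/C(=C\c3ccccc3[N+](=O)[O-])C2=O)cc1` and compound 3 `CN(C)c1ccc(/C=C2\CCC/C(=C\c3cccc([N+](=O)[O-])c3)C2=O)cc1` share one core and differ by 3-nitrophenyl in place of 2-nitrophenyl on a double-bonded chain carbon bound to a double-bonded ring carbon. In a functional assay on HL-60 cells (Homo sapiens) for cytotoxicity, with a stated time of 24 h (on this read-out lower numbers stand for higher toxicity in this test and higher numbers for lower toxicity in this test), compound 1 gives > 400000 nM. That figure is a limit of the assay and not a number (the limit of > 400000 nM in this assay, at which 1 of the 3 values shown sits). In this assay compound 3 gives 30000 nM, so the change produces an at least 13-fold lower number from compound 1 to compound 3 (1.12 log units; beyond the scatter). Compound 2 `COc1cc(/C=C2\CCC/C(=C\c3ccccc3[N+](=O)[O-])C2=O)cc(OC)c1OC` carries a different core; the difference between the two cores is not broken down here. In this assay compound 2 gives 3000 nM, the lowest of the two numbers shown. Compound 4 `COc1cc(/C=C2\CCC/C(=C\c3cccc([N+](=O)[O-])c3)C2=O)cc(OC)c1OC` is the unmeasured partner of compound 2 and is reached by 3-nitrophenyl in place of 2-nitrophenyl on a double-bonded chain carbon bound to a double-bonded ring carbon; the place of the change is worded identically for both pairs, so it is the same change. For compound 4 the step in this assay is expected to be a 3.0-fold lower number from compound 2 to compound 4 (0.48 log units; beyond the scatter), resting on an at least 13-fold lower number from compound 1 to compound 3 (1.12 log units; beyond the scatter), whose true size is uncertain because the starting point of an at least 13-fold lower number from compound 1 to compound 3 (1.12 log units; beyond the scatter) is a limit rather than a number. Compound 4 is therefore estimated at 1000 nM in this assay, with an expected range from 200 nM to 4000 nM.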

Compound 4, half-maximal cytotoxic concentration: 59000 nM
Compound 4: middle estimate off by 59-fold (1.77 log units), on the low side, and the stated range ends below it.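

In this assay the change from 2-nitrophenyl to 3-nitrophenyl gives a 20-fold higher number from compound 2 to compound 4 (1.29 log units; beyond the scatter), so it does not carry over from the core of compound 1 to the core of compound 2, and the two steps run in opposite directions: the same change on two cores in this assay, an at least 13-fold lower number (1.12 log units; beyond the scatter) from compound 1 to compound 3 and a 20-fold higher number (1.29 log units; beyond the scatter) from compound 2 to compound 4, at least 260-fold (2.41 log units) apart, beyond the scatter of two such steps.
Compound 1 sits at a limit of the assay, not at a number, which leaves the size of its step open: the limit of > 400000 nM in this assay, at which 1 of the 4 values shown sits.
These two pairs show that, in this series, the result of the nitro shift depends on the core it sits on, but they do not show what in the two cores sets the direction, or how the shift would behave on any other core.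

On these data alone, it remains open which of the two directions a further core would follow, for example one bearing a carboxylic acid or a morpholine group where compound 1 and compound 2 differ. Also open, as far as these compounds go, is whether an amine in place of the nitro group on the same phenyl ring would show the same dependence on the core.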